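The source may report more compounds than this note shows. Statements on the series, on what has been measured and on what is new or still open speak of the compounds shown alone.

Measured in a physicochemical assay for solubility, read by HPLC, using the shake flask method, measured as kinetic solubility, with a stated time of 2 h, at pH 7.4; on this read-out higher numbers stand for higher solubility and lower numbers for lower solubility:
compound 1, `Cc1cc(NCc2ccncc2)n2nc(C)c(-c3ccccc3)c2n1`: 134000 nM
compound 2, `Cc1cc(NCc2ccc3ccccc3n2)n2nc(C)c(-c3ccccc3)c2n1`: < 5000 nM
compound 3, `COc1ccc(-c2cnn3c(NCc4ccccn4)cc(C)nc23)cc1`: < 5000 nM

Compound 1 is the only one of the three that gives a number in this assay, at 134000 nM. For compound 2 the result is a limit of the assay, < 5000 nM, and not a number. Compound 3 likewise gives only a limit, < 5000 nM; it sits at the limit of < 5000 nM in this assay, at which 2 of the 3 values shown sit, so its standing among the three cannot be placed more closely than that.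

Compound 4, `Cc1cc(NCc2ccccn2)n2ncc(C3=CCC(F)(F)CC3)c2n1`, is the unmeasured analogue of compound 3. The change is 4,4-difluorocyclohex-1-en-1-yl in place of 4-methoxyphenyl on an aromatic carbon.

For the measured compounds named here, no measured pair of this series differs in just one place, so no step of this kind has been observed. Since compound 3 gives only a limit, the step to compound 4 in this assay is expected to be small and cannot be set against a firm starting number; the estimate means a number no lower from compound 3 to compound 4 (the limit leaves the size open), a change not expected to exceed the usual scatter. Compound 4 is expected to give about 5000 nM in this assay, within a range from 1000 nM to 30000 nM, with a fair chance that the assay again reports only a limit.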

Compound 4, solubility: 5000 nM
The estimate for compound 4 equals the measured number at the digits printed; measured number inside the range.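

Compounds 3 and 4 form the only pair shown that differs in just one place: on an aromatic carbon of a five-membered aromatic ring with 2 nitrogen, 4,4-difluorocyclohex-1-en-1-yl stands in place of 4-methoxyphenyl. Compound 3 gives < 5000 nM in this assay, which is a limit of the assay and not a number. With this change, this assay shows a number no lower from compound 3 to compound 4 (the limit leaves the size open), and compound 4 gives 5000 nM, a number that gives this position a firm reference point where compound 3 offered none: the limit of < 5000 nM in this assay, at which 2 of the 4 values shown sit.

Going by these compounds, the size of the step therefore stays unknown, and the pair cannot separate the loss of the aromatic ring, the double bond, the two fluorines and the loss of the methoxy group, since all of these change together. The compounds shown also leave open how this assay would read with a saturated cyclohexyl ring, a morpholine or a carboxylic acid on this aromatic carbon, and whether 4,4-difluorocyclohex-1-en-1-yl would behave alike on the core of compound 1.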